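Amide substituent variation on a stilbene-acrylamide series

The compounds below may be only part of what the source reports. "The series", "measured", "known", "first", "only" and "open" are said of these compounds alone.

Measured compounds:
Compound 1 `CCNC(=O)/C=C/c1c(/C=C/c2ccc(OC)cc2)cc(OC)cc1OC` gives 7060 nM in a functional assay on MCF7 cells (Homo sapiens) for inhibition, read by MTT assay, with a stated time of 48 h; a higher number here means a weaker inhibitor, a lower number a stronger inhibitor.
Compound 2 `CCCCN(CCCC)C(=O)/C=C/c1c(/C=C/c2ccc(OC)cc2)cc(OC)cc1OC` gives 3990 nM in this assay.

Within the data shown here, compound 1 stands with the highest of the two numbers so far; its nearest neighbour is compound 2, and the step of a 1.8-fold lower number from compound 1 to compound 2 (0.25 log units; within the scatter) is the only comparison available in the set, within the scatter.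

Compound 3 `COc1ccc(/C=C/c2cc(OC)cc(OC)c2/C=C/C(=O)N2CCC(c3ccccc3)CC2)cc1` is not yet measured in this assay. Relative to compound 1 the change is 4-phenylpiperidin-1-yl in place of ethylamino on a carbonyl carbon. Among the measured compounds shown here, the one measured step that bears on this change, a 1.8-fold lower number from compound 1 to compound 2 (0.25 log units; within the scatter), also replaces ethylamino on the carbonyl carbon with a larger group carrying no hydrogen-bond donor, and it did not move the number beyond the scatter. On that basis a change of similar size or smaller is expected here, with a lower number somewhat more likely than a higher one, as seen from compound 1 to compound 2.

Compound 3 is therefore estimated at 4500 nM in this assay, with a range of 1500 nM to 13000 nM; this expectation corresponds to a step of a 1.6-fold lower number from compound 1 to compound 3 (0.20 log units; within the scatter).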

Compound 3, half-maximal inhibitory concentration: 4230 nM
Estimate against measurement, compound 3: 1.1-fold (0.03 log units) above, and the stated range covers the measured number.
By their numbers in this assay, from the lowest: compounds 2, 3 and 1 (each within the scatter of the next).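

In this assay, replacing ethylamino on the carbonyl carbon with 4-phenylpiperidin-1-yl, which brings one non-aromatic and one aromatic six-membered ring and leaves no amide hydrogen, gives a 1.7-fold lower number from compound 1 to compound 3 (0.22 log units; within the scatter) and so does not move the number beyond the scatter. The earlier compounds had shown this only for an open-chain replacement, whereas the comparison between the two tertiary amides, a 1.1-fold higher number from compound 2 to compound 3 (0.03 log units; within the scatter), now shows that open dibutylamino chains and this ring-bearing group cannot be told apart here, so across compounds 1, 2 and 3 all changes at this place remain within the scatter. No measurement on hand accounts for this flat result.

From the compounds shown here alone, whether any group at this carbonyl carbon can shift the number beyond the scatter remains open, for example a 4-phenylpiperidin-1-yl group carrying an amine or a carboxylic acid on its phenyl ring, or morpholine in place of the piperidine. The compounds shown also share the same core and its methoxy groups, so they leave open how changes there would read in this assay, and whether such changes would make the amide group matter more.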